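This account rests on a few compounds, and the source may have more. Where it says the series, first, only, none or still open, it means among the compounds named here.

Three amides sharing one core have been tested in a functional assay on MDA-MB-231 cells (Homo sapiens) for antiproliferative activity, read by MTT assay, with a stated time of 72 h; a lower number here means a stronger inhibitor, a higher number a weaker inhibitor: compound 1 (`CC(C)(C)NC(=O)CCc1cccc2c1B(O)OC2`), compound 2 (`O=C(CCc1cccc2c1B(O)OC2)NCc1ccccc1`) and compound 3 (`O=C(CCc1cccc2c1B(O)OC2)Nc1nccs1`). Compound 1 reads > 100000 nM as a limit of the assay and not a number. Compound 2 reads > 100000 nM as a limit too. Compound 3 reads > 100000 nM as well, again only a limit, so it has no measured potency to build on. Within the data shown here, the series so far therefore gathers at a single point (the limit of > 100000 nM in this assay, at which 3 of the 3 values shown sit).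

Compound 4 (`O=C(CCc1cccc2c1B(O)OC2)Nc1ccc(F)cc1`) keeps the core and the amide and carries 4-fluorophenyl in place of 1,3-thiazol-2-yl on an amide-type nitrogen. Among the measured compounds shown here, all the measured steps changed the group at this same place (a step that the two limits leave unreadable from compound 1 to compound 2; a step that the two limits leave unreadable from compound 1 to compound 3; a step that the two limits leave unreadable from compound 2 to compound 3). None of them has a readable size, so they offer no sign of how far or in which direction a new group here could move the result. The expected outcome is no change beyond the scatter, and most likely another limit. The estimated step is small (a number no higher from compound 3 to compound 4 (the limit leaves the size open)). Compound 4 is estimated at 100000 nM with an expected range from 30000 nM to 150000 nM if a number appears at all.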

Compound 4, half-maximal inhibitory concentration: 440 nM
Estimate against measurement, compound 4: 230-fold (2.36 log units) above; measured number outside the range, below it.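

Putting 4-fluorophenyl in place of 1,3-thiazol-2-yl on the amide-type nitrogen gives an at least 220-fold lower number from compound 3 to compound 4 (2.35 log units; beyond the scatter) in this assay and shows that this one position can separate a limit from a measured potency while the core and the amide stay the same. The same entering group also gives an at least 220-fold lower number from compound 2 to compound 4 (2.35 log units; beyond the scatter) when it replaces benzyl and an at least 220-fold lower number from compound 1 to compound 4 (2.35 log units; beyond the scatter) when it replaces tert-butyl, and all three sizes are lower bounds that rest on limits. Among these compounds, the steps among compound 1, compound 2 and compound 3 cannot be read, so compound 4 is the only compound here that gives the series a number, and the rest remains a single point: the limit of > 100000 nM in this assay, at which 3 of the 4 values shown sit.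

Compound 3 also carries an aromatic ring at this position, so the compounds shown do not separate the part played by the fluorine from that of the carbon-only ring. Plain phenyl, 4-chlorophenyl or 4-methoxyphenyl on the same nitrogen would bear on that question, and how far the activity tolerates such changes remains open.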